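Swapping 4-Methoxyphenyl for 3,4-Dichlorophenyl on the Shared Core

The compounds below may be only part of what the source reports. "The series", "measured", "known", "first", "only" and "open" are said of these compounds alone.

In an ADME assay on NHDF cells (Homo sapiens) for cytotoxicity, read by MTT assay, with a stated time of 72 h (on this read-out lower numbers stand for stronger inhibition and higher numbers for weaker inhibition), compound 1 (`COc1cccc(/C=C2\CCC/C(=C\c3cccc(Cl)c3)C2=O)c1OC`) gives 21400 nM and compound 2 (`COc1cccc(/C=C2\CCC/C(=C\c3cccc(OC)c3OC)C2=O)c1`) gives 16400 nM as a pair within the scatter (a 1.3-fold lower number from compound 1 to compound 2 (0.12 log units; within the scatter)). Compound 3 (`COc1ccc(/C=C2\CCC/C(=C\c3cccc(OC)c3OC)C2=O)cc1`) stands highest of the three at 43500 nM on this read-out. Compound 4 (`COc1cccc(/C=C2\CCC/C(=C\c3ccc(Cl)c(Cl)c3)C2=O)c1OC`) differs from it by 3,4-dichlorophenyl in place of 4-methoxyphenyl (3,4-dichlorophenyl in place of 4-methoxyphenyl on a double-bonded chain carbon bound to a double-bonded ring carbon). Among the compounds with values here, two measured steps bear on this change: 4-methoxyphenyl in place of 3-chlorophenyl brought a modest rise (a 2.0-fold higher number from compound 1 to compound 3 (0.31 log units; beyond the scatter)), and 4-methoxyphenyl in place of 3-methoxyphenyl brought another (a 2.7-fold higher number from compound 2 to compound 3 (0.42 log units; beyond the scatter)). Leaving 4-methoxyphenyl is therefore expected to give a modest step to a lower number in this assay (a 2.4-fold lower number from compound 3 to compound 4 (0.38 log units; beyond the scatter)). Compound 4 is estimated at 18000 nM with an expected range from 7000 nM to 42000 nM overall.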

Compound 4, half-maximal inhibitory concentration: 25500 nM
Estimate against measurement, compound 4: 1.4-fold (0.15 log units) below; the measured number falls inside the stated range.
By their numbers in this assay, from the lowest: compounds 2, 1, 4 and 3 (each within the scatter of the next, the first and the last beyond it).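

In this assay, 3,4-dichlorophenyl in place of 4-methoxyphenyl on this double-bonded chain carbon stays within the scatter (a 1.7-fold lower number from compound 3 to compound 4 (0.23 log units; within the scatter)), unlike the two earlier steps to 4-methoxyphenyl. Compound 4 also cannot be told apart from compound 2 (a 1.6-fold higher number from compound 2 to compound 4 (0.19 log units; within the scatter)). Chloro in place of hydrogen on an aromatic carbon likewise gives a step within the scatter (a 1.2-fold higher number from compound 1 to compound 4 (0.08 log units; within the scatter)), so these chloro-bearing phenyl groups are not separated here.

No evidence is available on what lies behind these numbers. As far as these compounds go, whether an amine or a carboxylic acid on the phenyl ring at this place would give a step beyond the scatter remains open.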